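Trimming the triazole substituent: compound 2 to compound 4

The source may report more compounds than this note shows. Statements on the series, on what has been measured and on what is new or still open speak of the compounds shown alone.

Measured compounds:
Compound 1, `COc1ccc(-c2cn(C/C=C3\OC(=O)C(OCc4ccccc4)=C3OCc3ccccc3)nn2)cc1`. In a functional assay on CFPAC-1 cells (Homo sapiens) for antiproliferative activity, read by MTT assay, with a stated time of 72 h (on this read-out higher numbers stand for weaker inhibition and lower numbers for stronger inhibition), compound 1 reaches only the assay limit, > 100000 nM.
Compound 2, `O=C1O[C@H]([C@@H](O)Cn2cc(CNS(=O)(=O)c3ccc(F)cc3)nn2)C(OCc2ccccc2)=C1OCc1ccccc1`. In this assay compound 2 gives 34700 nM.
Compound 3, `O=C1O/C(=C\Cn2cc(-c3cccc(O)c3)nn2)C(OCc2ccccc2)=C1OCc1ccccc1`. In this assay compound 3 gives 33700 nM.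

Compound 2 holds the highest of the two numbers shown; its nearest neighbour is compound 3, and the two values lie within the scatter of each other, so no order between them can be drawn. Among the compounds with values here, the only measured step, an at least 2.9-fold lower number from compound 1 to compound 3 (0.47 log units; beyond the scatter), is a change of the aryl group on the triazole, and its size is known only as a bound because of the limit of > 100000 nM in this assay, at which 1 of the 3 values shown sits. That step does not bear on the change now at hand.

Compound 4, `O=C1O[C@H]([C@@H](O)Cn2ccnn2)C(OCc2ccccc2)=C1OCc1ccccc1`, differs from compound 2 by hydrogen in place of (((4-fluorophenyl)sulfonyl)amino)methyl on an aromatic carbon. Within the data shown here, no measured pair tests a loss of the whole substituent from the triazole, so the direction is open. Removing this arm is expected to give a weaker or similar number, with a wide range: compound 4 is estimated at 60000 nM, between 20000 nM and 200000 nM, a step of a 1.7-fold higher number from compound 2 to compound 4 (0.24 log units; within the scatter) that is expected rather than known.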

Compound 4, half-maximal inhibitory concentration: > 100000 nM
Compound 4 ended at the assay's limit; the forecaster's own chance of this, stated with the estimate: 35%; at least 1.6-fold (0.22 log units) between middle value and limit.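

In this assay, hydrogen in place of the (((4-fluorophenyl)sulfonyl)amino)methyl arm on the aromatic carbon of the five-membered ring with 3 nitrogen gives an at least 2.8-fold higher number from compound 2 to compound 4 (0.45 log units; beyond the scatter). Compound 4 stands at a limit of the assay, > 100000 nM, so this step is known only as a bound: the limit of > 100000 nM in this assay, at which 2 of the 4 values shown sit. The earlier step exchanged one aryl group for another, whereas this one shows that, on this core, the arm is needed for a reading short of the limit.

Which part of the arm counts stays open, and an aminomethyl group or a plain methyl on this carbon would separate the sulfonyl and 4-fluorophenyl portions from the linking carbon. From the compounds shown here alone, whether any group here can bring the number well under that of compound 2, 34700 nM, also remains open.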